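A few compounds are considered here, and "the series" means these few. Any claim that something is new, unique, unknown or untested is made for them only; others in the source may bear on it.

Compound 1 `Nc1ccccc1/C=C/c1ccc(O)cc1`, compound 2 `Nc1cccc(/C=C/c2ccccc2O)c1` and compound 3 `COc1cccc(/C=C/c2ccccc2O)c1` have been tested in a functional assay on HT-29 cells (Homo sapiens) for inhibition, read by MTT assay, with a stated time of 2 days; a lower number here means a stronger inhibitor, a higher number a weaker inhibitor. For compound 1 only a limit is reported, > 100 ug/mL, and this is the limit of > 100 ug/mL in this assay, at which 1 of the 3 values shown sits. In this assay compound 2 gives 30.4 ug/mL, and compound 3 gives 26 ug/mL. Compound 2 and compound 3 differ in one place, (methoxy in place of amino on an aromatic carbon), and that step is a 1.2-fold lower number from compound 2 to compound 3 (0.07 log units; within the scatter). Compound 1 and compound 2 are built from the same atoms joined differently, and the difference between the two cores is not broken down here.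

Compound 4 `COc1ccccc1/C=C/c1ccc(O)cc1` has not yet been measured in this assay. It differs from compound 1 by methoxy in place of amino on an aromatic carbon. This is the same kind of change as from compound 2 to compound 3, but the place differs: in compound 4 the new group sits ortho to a group of 9 heavy atoms, whereas in compound 3 it sits meta to a group of 9 heavy atoms. The expectation for compound 4 rests on compound 1 giving only a limit, > 100 ug/mL, and on the step of a 1.2-fold lower number from compound 2 to compound 3 (0.07 log units; within the scatter) lying within the scatter. Compound 4 is therefore expected to stay weak in this assay, with an estimated value of about 120 ug/mL, which would mean an expected step that the limit leaves unreadable from compound 1 to compound 4. The estimate for compound 4 is expected to fall between 40 ug/mL and 300 ug/mL.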

Compound 4, half-maximal inhibitory concentration: 24 ug/mL
Estimate against measurement, compound 4: 5.0-fold (0.70 log units) above; the measured number lies below the stated range.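

In this assay, methoxy in place of amino on an aromatic carbon gives an at least 4.1-fold lower number from compound 1 to compound 4 (0.61 log units; beyond the scatter). Carried from one core to another in this series, the change therefore does not give one fixed step: the same change on two cores in this assay, a 1.2-fold lower number (0.07 log units; within the scatter) from compound 2 to compound 3 and an at least 4.1-fold lower number (0.61 log units; beyond the scatter) from compound 1 to compound 4, at least 3.5-fold (0.55 log units) apart, beyond the scatter of two such steps. This does not show how large the step on the core of compound 1 really is, nor whether the cores themselves or the place of the new group set the gap, and compound 1 is known only as a limit of the assay: the limit of > 100 ug/mL in this assay, at which 1 of the 4 values shown sits.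

The compounds shown leave open whether the same uneven result would appear with other groups at this place, such as ethoxy, a dimethylamino group or a single fluorine atom in place of the amino group. They also leave open how the methoxy group of compound 4, ortho to a group of 9 heavy atoms, would behave at other places on the same ring.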